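This account rests on a few compounds, and the source may have more. Where it says the series, first, only, none or still open, it means among the compounds named here.

Measured compounds in a physicochemical assay for acid dissociation:
- compound 1 `COc1ccccc1Oc1ccc2c(NCCCNCc3ccco3)ccnc2c1` gives 9.28
- compound 2 `COc1ccc(F)cc1CNCCCNc1ccnc2cc(C3CCCCC3)ccc12` gives 9.47
- compound 3 `COc1cccc(CNCCCNc2ccnc3cc(Cc4ccccc4)ccc23)c1O` gives 9.47

Compound 3 matches compound 2 at the digits shown in this assay, and the gap from compound 3 to compound 1 is within the usual scatter of repeated measurements, so the three numbers are not told apart by this assay. Among the measured compounds shown here, no pair of measured compounds differs in only one place, so no single-point step is available from the data.

Compound 4 `COc1cccc(Oc2ccc3c(NCCCNCc4cccc(OC)c4O)ccnc3c2)c1` is the next compound, not yet measured. It differs from compound 3 by 3-methoxyphenoxy in place of benzyl on an aromatic carbon. Compound 1 carries a related methoxyphenoxy group on its core and gives 9.28, a number within the scatter of the value of compound 3, so the three measured values give no sign that exchanging the group at this aromatic carbon moves the read-out beyond the scatter.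

For compound 4 the step from compound 3 is expected to be a number 0.12 log units lower from compound 3 to compound 4 (within the scatter), which is no change beyond the scatter. Compound 4 is therefore estimated at 9.35, with a range from 9 to 9.7.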

Compound 4, acid dissociation constant: 9.28
Compound 4: middle estimate off by 0.07 log units, on the high side; the range from low to high includes it.
By their numbers in this assay, from the lowest: compounds 1, 4, 2 and 3 (each within the scatter of the next).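

Among the compounds shown here, the first one-place step at this aromatic carbon of the shared core reads, in this assay, a number 0.19 log units lower from compound 3 to compound 4 (within the scatter) for 3-methoxyphenoxy in place of benzyl. At this position, a group of 9 heavy atoms with 2 hydrogen-bond acceptors therefore replaces one of 7 heavy atoms with 0 hydrogen-bond acceptors without a change beyond the scatter in this read-out, which is now shown on a matched pair and no longer rests on comparing compounds that differ in several places. No evidence at hand bears on why the step has this size, so it stands as an observation on this one pair.

The compounds shown leave open whether any group on this aromatic carbon can move the read-out beyond the scatter, since neither benzyl nor 3-methoxyphenoxy does so and a group such as a primary amine or a carboxylic acid is not among them. Also open, as far as these compounds go, is whether the same exchange gives a comparable step on another side chain, or with a longer chain joining the shared core to the benzylic amine.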